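Moving the Chlorine: From 2-Chlorophenyl to 4-Chlorophenyl

This account rests on a few compounds, and the source may have more. Where it says the series, first, only, none or still open, it means among the compounds named here.

Compound 1 (`C/C(=N\NC(=O)Cn1c(=O)c(C)nc2ccccc21)c1ccccc1Cl`) is the starting point, and in a functional assay on C8166 cells (Homo sapiens) for cytotoxicity, read by MTT assay, with a stated time of 72 h (a lower number here means that less compound is tolerated, a higher number that more compound is tolerated), compound 1 gives > 543000 nM, which is a limit of the assay and not a number. Compound 2 (`COc1ccc(/C=N/NC(=O)Cn2c(=O)c(C)nc3ccccc32)cc1OC`), which carries a different side group on the same shared core, gives > 526000 nM, and this too is a limit. Neither result is an exact reading, so compound 1 cannot be ranked against compound 2.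

The next compound, compound 3 (`C/C(=N\NC(=O)Cn1c(=O)c(C)nc2ccccc21)c1ccc(Cl)cc1`), contains the same atoms as compound 1, joined differently: 4-chlorophenyl in place of 2-chlorophenyl on a carbon with a double bond to nitrogen. Here 4-chlorophenyl stands in place of 2-chlorophenyl on a carbon with a double bond to nitrogen. Among the measured compounds shown here, no measured pair in this small set shows what such a change does in this assay, so no step beyond the usual scatter is expected. The estimated step of an at least 1.0-fold lower number from compound 1 to compound 3 (0.03 log units; that floor lies within the scatter) is accordingly small. This expectation rests on compound 1, whose > 543000 nM is a limit. The estimated value for compound 3 is 500000 nM, with an expected range from 150000 nM to 600000 nM.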

Compound 3, half-maximal cytotoxic concentration: > 543000 nM
Compound 3: no number, only a limit; the forecaster's own chance of this, stated with the estimate: 65%; middle value at least 1.0-fold (0.03 log units) from the limit.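

In this assay compound 3 gives > 543000 nM, which is a limit of the assay and not a number. Compound 1 also stands at a limit, and no step can be read between compound 1 and compound 3. The compounds shown leave open where the exact cytotoxic concentrations lie, and whether 4-chlorophenyl in place of 2-chlorophenyl changes them at all.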